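Swapping an amino for a methyl on the core of compound 3

The source may hold more compounds than are shown below. What is called first, only, known or untested is meant among the compounds shown, and "the series" means these compounds.

Compound 1 `CC(=O)Nc1nccc(-c2ccncc2)n1`: in a functional assay on the whole organism for inhibition, with Rattus norvegicus as the target, with stated times of 1 h and 3.5 h, at a dose of 100 mg/kg by the oral route (on this read-out higher numbers stand for more inhibition at the one dose given (going by the name of the read-out) and lower numbers for less inhibition), compound 1 gives 52%.
Compound 2 `Cc1cncnc1-c1ccncc1`: in this assay compound 2 gives 50%.
Compound 3 `CC(C)(C)C1CCc2nc(N)ncc2C1`: in this assay compound 3 gives 41%.

Of the compounds shown here, three have been measured so far. Compound 3 sits below compound 1 by a gap that lies beyond the usual scatter of this kind of measurement, while its number and that of compound 2 fall within the scatter of each other, so those two cannot be told apart.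

Compound 4 `Cc1ncc2c(n1)CCC(C(C)(C)C)C2` is the untested partner of compound 3: methyl in place of amino on an aromatic carbon. The change is small in atom count, yet it removes the only hydrogen-bond donor of that position. Within the data shown here, no pair of measured compounds differs in just this one way, so nothing shows directly how such a swap plays out in this assay. One hint exists: compound 2 also carries a methyl on its core and no amino, and in this assay compound 2 gives 50%, close to the number of compound 3, which suggests a change of modest size at most.

Compound 4 is therefore expected to give 38%, with a likely range from 15% to 60%. This estimate means a step of a number 3 percentage points lower from compound 3 to compound 4 (within the scatter), expected to stay within the scatter rather than beyond it.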

Compound 4, a percentage reported as inhibition, in the whole organism at one dose (the size of the read-out at that dose, not a potency): < 5%
Compound 4 gave a limit, no number (the forecaster's own chance of this, stated with the estimate: 0%); middle value at least 33 percentage points away from the limit.
By their numbers in this assay, from the lowest: compounds 3, 2 and 1 (each within the scatter of the next, the first and the last beyond it). At a limit, below all of these: compound 4.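

In this assay, placing methyl instead of amino on the aromatic carbon between two ring nitrogen atoms gives a step of a number at least 36 percentage points lower from compound 3 to compound 4 (beyond the scatter). For compound 4, the value < 5% is a limit of the assay and not a number. This pair differs in one place only, so it gives the first direct sign that this position matters on this core: a single heavy atom exchanged here, with the amino group leaving and the methyl group entering, separates a compound with a clear reading from one at the limit, something that compound 2, with its methyl on a core that differs in more than one place, could not show.

The pair cannot separate the loss of the amino group from the arrival of the methyl group, and a plain hydrogen at this position, or a hydroxyl group, would help to tell those two apart. Methylamino or dimethylamino at the same carbon would further show whether the amino group can be extended at all, or whether only the unsubstituted amino group holds up the reading on this core.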